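Trifluoromethylphenyl in Place of Fluorophenyl on the Amide

A few compounds are considered here, and "the series" means these few. Any claim that something is new, unique, unknown or untested is made for them only; others in the source may bear on it.

Compound 2, `COc1cc(-c2cc(C(=O)O)c3ccccc3n2)ccc1OCC(=O)Nc1ccc(F)cc1`, shares its core with compound 1, `COc1cc(-c2cc(C(=O)O)c3ccccc3n2)ccc1OCC(=O)Nc1cccc(C)c1`, and the two differ only in the aryl group on the amide nitrogen. In a physicochemical assay for lipophilicity, using the shake flask method, in phosphate buffer, measured as octanol-water partition, at pH 7.4 (a higher number here means a more lipophilic compound, a lower number a more polar compound), compound 1 gives 1.5 and compound 2 gives 1.1. Among the measured compounds shown here, compound 2 thus stands as the lower of the two numbers, with compound 1 the nearest neighbour, and the single measured step reads a number 0.40 log units lower from compound 1 to compound 2 (beyond the scatter).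

Compound 3, `COc1cc(-c2cc(C(=O)O)c3ccccc3n2)ccc1OCC(=O)Nc1ccccc1C(F)(F)F`, carries the change (2-(trifluoromethyl)phenyl in place of 4-fluorophenyl on an amide-type nitrogen). For the measured compounds named here, no measured step swaps this pair of groups; the only step at hand, from compound 1 to compound 2, exchanges an aryl group at the same amide nitrogen and moves this assay by a modest amount, so a change at the same place can be expected to move the number by a similar or somewhat larger amount. Compound 3 is therefore expected to lie higher than compound 2, by an estimated a number 0.50 log units higher from compound 2 to compound 3 (beyond the scatter). In this assay compound 3 is estimated at 1.6, within a range from 1.1 to 2.1.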

Compound 3, distribution coefficient: 1.3
Beside the measured number, compound 3's estimate is 0.30 log units above it, within the range that was stated.
By their numbers in this assay, from the lowest: compounds 2, 3 and 1 (each within the scatter of the next, the first and the last beyond it).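

At the amide-type nitrogen, 2-(trifluoromethyl)phenyl in place of 4-fluorophenyl gives a number 0.20 log units higher from compound 2 to compound 3 (within the scatter) in this assay, while 2-(trifluoromethyl)phenyl in place of 3-methylphenyl gives a number 0.20 log units lower from compound 1 to compound 3 (within the scatter) in the same read-out. Compound 3 therefore cannot be told apart from either of the other two compounds, although those two are separated by a step beyond the scatter, a number 0.40 log units lower from compound 1 to compound 2 (beyond the scatter), so the three aryl groups do not fall into separate levels in this small set. The position also accepts 2-(trifluoromethyl)phenyl, which has more heavy atoms and more fluorine than 4-fluorophenyl, with a number that stays within the scatter of compound 2, and nothing at hand gives a reason for this result.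

The compounds shown leave open whether a group of another kind on this nitrogen, such as a phenyl ring carrying an amine or a longer alkyl chain in place of the aryl ring, would give a number beyond the scatter of all three. They also leave open whether these steps would keep their size if the carboxylic acid on the shared core gave way to an amide.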